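Phenyl for methyl on the ring nitrogen

The source may report more compounds than this note shows. Statements on the series, on what has been measured and on what is new or still open speak of the compounds shown alone.

In a functional assay on A549 cells (Homo sapiens) for inhibition, read by MTT assay, with a stated time of 48 h (on this read-out higher numbers stand for weaker inhibition and lower numbers for stronger inhibition), compound 1 `Cc1ccc(-n2cc(NC(=O)c3cccc(NS(=O)(=O)c4ccccc4)c3)cn2)cc1` gives 18900 nM and compound 2 `COc1cccc(-n2cc(NC(=O)c3cccc(NS(=O)(=O)c4ccc(Cl)cc4)c3)cn2)c1` gives 44400 nM. Compound 3 `Cn1cc(NC(=O)c2ccc(NS(=O)(=O)c3ccccc3)cc2)cn1` returns only a limit, > 100000 nM. On the numbers shown compound 3 therefore sits at the limit of > 100000 nM in this assay, at which 1 of the 3 values shown sits, with no number behind it. Compound 4 `O=C(Nc1cnn(-c2ccccc2)c1)c1ccc(NS(=O)(=O)c2ccccc2)cc1`, not yet measured, differs from compound 3 by phenyl in place of methyl on an aromatic nitrogen. Compounds 1 and 2, which carry an aryl group at that position, both fall inside the measurable range, so a gain beyond the usual scatter is expected, the step of an at least 2.0-fold lower number from compound 3 to compound 4 (0.30 log units; that floor lies within the scatter) being the expected size in this assay. For compound 4 the estimate is 50000 nM, between 15000 nM and 150000 nM, with a fair chance of another limit.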

Compound 4, half-maximal inhibitory concentration: 87100 nM
Compound 4: middle estimate off by 1.7-fold (0.24 log units), on the low side; measured number inside the range.
By their numbers in this assay, from the lowest: compound 1; then compounds 2 and 4 (each within the scatter of the next). At a limit, above all of these: compound 3.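

Phenyl in place of methyl on the aromatic nitrogen gives, in this assay, an at least 1.1-fold lower number from compound 3 to compound 4 (0.05 log units; that floor lies within the scatter). With this change, the core of compound 4 gives a measurable number, 87100 nM, so an aryl group at this position is now tied to a reading on a single change. The true size of the step stays unknown because compound 3 gives only a limit: the limit of > 100000 nM in this assay, at which 1 of the 4 values shown sits.

Open, from the compounds shown here alone, is how an amine, a carboxylic acid or a longer chain on this nitrogen would read. Also open, going by these compounds, is whether the step carries over to the core of compound 1.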